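Replacing a hydroxyphenyl with a pyridyl at alpha-2C

The source may hold more compounds than are shown below. What is called first, only, known or untested is meant among the compounds shown, and "the series" means these compounds.

Compound 3 `CC(Oc1ccccc1-c1ccccc1O)C1=NCCN1` was examined in a functional assay on CHO cells for agonist activity at Alpha-2C adrenergic receptor (Homo sapiens); a lower number here means a smaller maximal response, a higher number a larger maximal response. In this assay compound 3 gives < 0.3, which is a limit of the assay and not a number. Two close relatives stand at the same limit. In this assay compound 1 `CC(Oc1ccccc1-c1ccccc1[N+](=O)[O-])C1=NCCN1` gives < 0.3, again a limit. In this assay compound 2 `CC(Oc1ccccc1-c1ccccc1)C1=NCCS1` gives < 0.3, also a limit. Among the compounds with values here, the only step measured between two compounds that differ in one place is a step that the two limits leave unreadable from compound 1 to compound 3, and its size cannot be read because of the limit of < 0.3 in this assay, at which 3 of the 3 values shown sit.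

Compound 4 `CC(Oc1ccccc1-c1cccnc1)C1=NCCN1` differs from compound 3 in one place: pyridin-3-yl in place of 2-hydroxyphenyl on an aromatic carbon. Within the data shown here, no measured step concerns this change, and the one step that exists is itself unreadable. With every measured value at the limit, the expectation for the step to compound 4 is one that stays near that limit, a step that the limit leaves unreadable from compound 3 to compound 4. Compound 4 is therefore estimated at 0.2 in this assay, with a range from 0.05 to 0.4, and most likely reported only as a limit.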

Compound 4, intrinsic activity: the largest response reached, as a fraction of the reference agonist's: 1
Beside the measured number, compound 4's estimate is 0.80 below it; the measured number lies above the stated range.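

In this assay, pyridin-3-yl in place of 2-hydroxyphenyl gives a number at least 0.70 higher from compound 3 to compound 4 (beyond the scatter), so this place on the aromatic ring can carry a change that moves the maximal response well clear of the limit. Within the data shown here, the change swaps a ring of carbon only, with a hydroxy group, for a ring holding a nitrogen and no hydrogen-bond donor, and this is the first readable step. Its size is bounded and not exact, and the step from compound 1 to compound 3 stays unreadable, because those values are limits and not numbers: the limit of < 0.3 in this assay, at which 3 of the 4 values shown sit.

A single change removes the hydroxy group and adds the ring nitrogen, so the compounds shown do not separate these two parts. Also open, on these data alone, is how pyridin-4-yl, or a phenyl ring bearing an amine or a carboxylic acid, would behave at this place.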